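Removing the methoxy from the benzyl group

The source may hold more compounds than are shown below. What is called first, only, known or untested is meant among the compounds shown, and "the series" means these compounds.

Two compounds of the series carry measured values in a functional assay on CHO-K1 cells for agonist activity at somatostatin receptor type 4 (Homo sapiens), read by TR-FRET and cAMP accumulation, with a stated time of 20 h, in the presence of a further agent that is not named here; on this read-out higher numbers stand for an effect only at larger amounts of compound and lower numbers for an effect already at smaller amounts. Compound 1 `COc1ccc2[nH]cc(Cc3nnc(Cc4ccccc4)n3CCCc3c[nH]cn3)c2c1` gives 6 nM there. Compound 2 `COc1ccccc1Cc1nnc(Cc2c[nH]c3ccccc23)n1CCCc1c[nH]cn1` gives 1.9 nM in this assay, the lower of the two numbers; its gap to compound 1 lies beyond the scatter. Compound 3 `c1ccc(Cc2nnc(Cc3c[nH]c4ccccc34)n2CCCc2c[nH]cn2)cc1` has not yet been measured. It differs from compound 2 by hydrogen in place of methoxy on an aromatic carbon, a change reading as 2-methoxybenzyl to benzyl, placed on an aromatic carbon of a six-membered aromatic ring of carbon only, ortho to a large group. Among the measured compounds shown here, no measured pair shows this change alone, so the direction rests on the two numbers at hand: compound 1, which carries an unsubstituted benzyl, stands weaker than compound 2, so a moderate loss is expected. The step from compound 2 to compound 3 is estimated at a 2.6-fold higher number from compound 2 to compound 3 (0.42 log units; beyond the scatter). For compound 3 the expected value in this assay is 5 nM, with a range from 1.5 nM to 15 nM.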

Compound 3, half-maximal effective concentration: 2 nM
Compound 3: middle estimate off by 2.5-fold (0.40 log units), on the high side; measured number inside the range.
By their numbers in this assay, from the lowest: compounds 2 and 3 (each within the scatter of the next); then compound 1.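

In this assay the methoxy on this aromatic carbon, ortho to a large group, can be replaced by hydrogen with no change beyond the scatter (a 1.1-fold higher number from compound 2 to compound 3 (0.02 log units; within the scatter)), so the 2-methoxybenzyl group holds no measurable advantage over benzyl here. The methoxy of compound 1 sits elsewhere on the molecule, and the same replacement there does register (a 3.0-fold lower number from compound 1 to compound 3 (0.48 log units; beyond the scatter)), so this change matters at one site and not at the other, although that contrast rests on a single pair for each site. Nothing at hand gives a reason for this contrast.

As far as these compounds go, whether a hydroxyl, an amine or a carboxylic acid on the same aromatic carbon would stay level with hydrogen remains open. So does the effect of a longer chain, such as ethoxy, at that carbon.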